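The source may report more compounds than this note shows. Statements on the series, on what has been measured and on what is new or still open speak of the compounds shown alone.

Measured so far:
- compound 1, `Nc1cc(N)c2nc(-c3ccccc3)c(NCc3ccc(Cl)c(Cl)c3)nc2c1`: 2090 nM
- compound 2, `Nc1cc(N)c2nc(-c3ccccc3)c(Oc3ccc(F)cc3)nc2c1`: 23400 nM
- compound 3, `CCOC(=O)[C@H](CCC(=O)O)NC(=O)c1ccc(Oc2nc3cc(N)cc(N)c3nc2-c2ccccc2)cc1`: < 100000 nM

The series is followed in a functional assay on U-251 cells (Homo sapiens) for inhibition, read by sulforhodamine B assay, with a stated time of 48 h; on this read-out higher numbers stand for weaker inhibition of growth and lower numbers for stronger inhibition of growth. Compound 2 carries the highest of the two numbers recorded there; the nearest number is that of compound 1, which lies well below it, beyond the usual scatter. For compound 3 only a limit is recorded, (the limit of < 100000 nM in this assay, at which 1 of the 3 values shown sits), so it gives no number to compare.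

The next step replaces the side arm of compound 2 to give compound 4, `Nc1cc(N)c2nc(-c3ccccc3)c(NCc3ccc(F)cc3)nc2c1`: (4-fluorobenzyl)amino in place of 4-fluorophenoxy on an aromatic carbon. Compound 2 and compound 4 thus share the core and the fluorine on the pendant ring and differ only in how that ring is joined to the core.

For the measured compounds named here, no measured pair differing in one place is available to size this step. Going by the values given here, compound 1, the only other compound with a number, also joins its pendant ring to the core through nitrogen and sits far below compound 2 in this assay, which is the one pointer to direction. Compound 4 is therefore expected to move toward stronger inhibition, by a 3.9-fold lower number from compound 2 to compound 4 (0.59 log units; beyond the scatter), although less far than compound 1 reaches. The estimate for compound 4 in this assay is 6000 nM, with a range from 1500 nM to 24000 nM.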

Compound 4, concentration for 50% growth inhibition: 1580 nM
Beside the measured number, compound 4's estimate is 3.8-fold (0.58 log units) above it; low and high end bracket the measured number.
By their numbers in this assay, from the lowest: compounds 4 and 1 (each within the scatter of the next); then compound 2.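

In this assay, the exchange at this position, on an aromatic carbon next to the ring nitrogen, gives a 15-fold lower number from compound 2 to compound 4 (1.17 log units; beyond the scatter), the first size measured for a change of how the pendant ring is joined to the core. The substitution on the pendant ring counts for far less among these compounds: with the (benzyl)amino join kept, 4-fluorophenyl in place of 3,4-dichlorophenyl gives a 1.3-fold lower number from compound 1 to compound 4 (0.12 log units; within the scatter), a step within the scatter. Of the two single changes now read, only the change of join moves the number beyond the scatter, although this holds for just one step of each kind.

That change swaps the oxygen for a nitrogen carrying a hydrogen and also adds a carbon, so the compounds shown cannot separate the two, and a 4-fluorobenzyloxy group or a 4-fluoroanilino group would be needed to read each part alone, while a longer chain such as (4-fluorophenethyl)amino would test the length further. What lies behind the large step also stays open, as nothing measured here bears on a cause.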